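The source may hold more compounds than are shown below. What is called first, only, known or untested is meant among the compounds shown, and "the series" means these compounds.

Working notes on the series. In an assay on membranes from HEK293 cells for displacement of a labelled ligand from Translocator protein (Homo sapiens), read by scintillation counting, with a stated time of 90 min (a lower number here means a stronger inhibitor, a higher number a weaker inhibitor), compound 1 `CC(=O)N(Cc1ccc(OC(C)C)cc1)c1cc(C)cc(C)c1` gives 823 nM. Compound 2 `CC(=O)N(Cc1ccc(OCc2ccccc2)cc1)c1cc(C)cc(C)c1` carries benzyl in place of isopropyl on an oxygen on an aromatic ring and in this assay compound 2 gives 377 nM, so that a 2.2-fold lower number from compound 1 to compound 2 (0.34 log units; beyond the scatter). Among the measured compounds shown here, compound 3 `CCN(CC)C(=O)CN(Cc1ccc(OC(C)C)cc1)c1cc(C)cc(C)c1` gives 2240 nM in this assay, and a 2.7-fold higher number from compound 1 to compound 3 (0.43 log units; beyond the scatter); compound 3 therefore stands with the highest number of the three measured so far, with compound 2 the furthest from it.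

Compound 4 `CCN(CC)C(=O)CN(Cc1ccc(OCc2ccccc2)cc1)c1cc(C)cc(C)c1` is not yet measured. For the measured compounds named here, it differs from compound 3 by benzyl in place of isopropyl on an oxygen on an aromatic ring, which is the same change as the one from compound 1 to compound 2, made at the same place. The two cores differ by (diethylcarbamoyl)methyl in place of acetyl on a nitrogen on an aromatic ring.

Going by the values given here, only one earlier instance of this change is known, so the expectation rests on a single pair. Compound 4 is expected to show a step of about a 2.2-fold lower number from compound 3 to compound 4 (0.35 log units; beyond the scatter) in this assay, set beside the earlier step because a 2.2-fold lower number from compound 1 to compound 2 (0.34 log units; beyond the scatter) gave a modest lowering. Compound 4 is thus estimated at 1000 nM in this assay, with a range from 450 nM to 2500 nM to cover the scatter around a single reference step.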

Compound 4, inhibition constant: 433 nM
Compound 4: the middle estimate sits 2.3-fold (0.36 log units) above what was measured, outside the stated range (below it).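

In this assay benzyl in place of isopropyl again lowers the number, with a 5.2-fold lower number from compound 3 to compound 4 (0.71 log units; beyond the scatter), and this step does not differ from the earlier one on the core of compound 1 beyond the scatter: the same change on two cores in this assay, a 2.2-fold lower number (0.34 log units; beyond the scatter) from compound 1 to compound 2 and a 5.2-fold lower number (0.71 log units; beyond the scatter) from compound 3 to compound 4, 2.4-fold (0.37 log units) apart, within the scatter of two such steps. The other change, (diethylcarbamoyl)methyl in place of acetyl, now reads a 1.1-fold higher number from compound 2 to compound 4 (0.06 log units; within the scatter), and although this step lies within the scatter while the earlier one lay beyond it, the two steps themselves do not differ beyond the scatter: the same change on two cores in this assay, a 2.7-fold higher number (0.43 log units; beyond the scatter) from compound 1 to compound 3 and a 1.1-fold higher number (0.06 log units; within the scatter) from compound 2 to compound 4, 2.4-fold (0.37 log units) apart, within the scatter of two such steps. Both changes thus carry across these two cores without a measurable difference in step size, but a single pair of cores fixes no exact size for either step and does not show that either would carry to another core.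

Still open, going by these compounds, is whether the step holds for other groups on the oxygen on the aromatic ring, such as a longer chain or a substituted benzyl. Also open, on these data alone, is how an amine or a carboxylic acid in place of the (diethylcarbamoyl)methyl amide would read.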